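Hydroxy in Place of Hydroxymethyl: A Small Expected Step

A few compounds are considered here, and "the series" means these few. Any claim that something is new, unique, unknown or untested is made for them only; others in the source may bear on it.

In an assay on isolated protein for inhibition of sphingosine 1-phosphate receptor 5 (Homo sapiens), tested at 25 uM (on this read-out lower numbers stand for less inhibition and higher numbers for more inhibition at the one concentration tested (going by the name of the read-out)), compound 1 `Cc1ccsc1-c1ccc(C(=O)Nc2c(C)cc(CO)cc2C)o1` is reported as "not active" (no number reported), so no single number marks where it stands. Within the data shown here, compound 2 `Cc1cc(CN)cc(C)c1NC(=O)c1ccc(-c2cc(Cl)ccc2Cl)o1` differs from it at several places; in this assay compound 2 gives 90%, and the two results show only one compound reported as not active and one compound with a high inhibition number in this assay, without a single step between them. Compound 3 `Cc1ccsc1-c1ccc(C(=O)Nc2c(C)cc(O)cc2C)o1`, not yet measured, carries hydroxy in place of hydroxymethyl on an aromatic carbon relative to compound 1. Among the measured compounds shown here, no measured pair shows this change, and no step beyond the usual scatter is expected in this assay in either direction. Compound 3 is therefore expected to give 15%, within 0% to 45%.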

Compound 3, a percentage reported as inhibition, at one concentration (the size of the read-out at that concentration, not a potency): "not active" (no number reported)
Compound 3 has no reported number here, and the estimate cannot be compared.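

In this assay compound 1 gives "not active" (no number reported) and compound 3 gives "not active" (no number reported) so no step can be read between them, and no evidence bears on this result. On these data alone, whether hydroxy in place of hydroxymethyl alters inhibition in a compound with a reported number remains open.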